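Rearranged Group on the Chain of Compound 1

The source may report more compounds than this note shows. Statements on the series, on what has been measured and on what is new or still open speak of the compounds shown alone.

Measured in a functional assay on MIA PaCa-2 cells (Homo sapiens) for antiproliferative activity, read by MTT assay, with a stated time of 72 h; on this read-out lower numbers stand for stronger inhibition and higher numbers for weaker inhibition:
- compound 1 `O=C1O/C(=C\Cn2cnc3c(F)nc(F)c(Cl)c32)C(OCc2ccccc2)=C1OCc1ccccc1`: 78000 nM
- compound 2 `O=C1NC(O)(/C=C\n2cc(I)c3c(Cl)ncnc32)C(OCc2ccccc2)=C1OCc1ccccc1`: 22600 nM

Only these two compounds have been measured so far. Compound 1 stands at the higher, weaker end at 78000 nM, and compound 2 gives a lower number, 22600 nM, with a gap beyond the usual scatter. The two differ in more than one place, so their gap says little about a single change.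

Compound 3 `O=C1O/C(=C\Cn2cnc3c(Cl)c(F)nc(F)c32)C(OCc2ccccc2)=C1OCc1ccccc1` has the same atoms as compound 1, joined differently: a group of 12 heavy atoms (6 carbon, 3 nitrogen, 2 fluorine, 1 chlorine; one five-membered aromatic ring with 2 hetero atoms, one six-membered aromatic ring with 1 hetero atom) in place of a group of 12 heavy atoms (6 carbon, 3 nitrogen, 2 fluorine, 1 chlorine; one five-membered aromatic ring with 2 hetero atoms, one six-membered aromatic ring with 1 hetero atom), on a saturated chain carbon bound to a double-bonded chain carbon. The change lies in the group on a saturated chain carbon bound to a double-bonded chain carbon. Within the data shown here, no measured step shows the effect of such a change in this assay, so no shift beyond the scatter is expected. The expected step is a 1.4-fold lower number from compound 1 to compound 3 (0.15 log units; within the scatter). For compound 3 the estimated value is 55000 nM, with an expected range of 20000 nM to 130000 nM.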

Compound 3, half-maximal inhibitory concentration: > 100000 nM
Compound 3 was reported as a limit; the forecaster's own chance of this, stated with the estimate: 15%; middle value at least 1.8-fold (0.25 log units) away from the limit.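

In this assay compound 3 gives > 100000 nM, which is a limit of the assay and not a number. Among these compounds, this is the first step that isolates a change in the group on a saturated chain carbon bound to a double-bonded chain carbon: with the same atoms joined differently, the reading is an at least 1.2-fold higher number from compound 1 to compound 3 (0.10 log units; that floor lies within the scatter), so this rearrangement brought no lower number, while the floor of the step does not establish a loss beyond the scatter. The step rests on a limit: the limit of > 100000 nM in this assay, at which 1 of the 3 values shown sits.

From the compounds shown here alone, the true size of the step from compound 1 therefore remains open. Also open, going by these compounds, is whether an amine or a carboxylic acid on this group, or a longer chain at this place, would move the number in this assay.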